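Amine side-chain swap and clearance in rat liver microsomes

This account rests on a few compounds, and the source may have more. Where it says the series, first, only, none or still open, it means among the compounds named here.

Compound 2 `CCN(CC)CCN(C)c1ccc(Cn2c(=O)[nH]c3c(N)nc(C(F)(F)F)cc32)cn1` is the anchor of the comparison. In an in vitro ADME assay on microsomes from liver (Rattus norvegicus) for pharmacokinetics (on this read-out lower numbers stand for slow clearance and higher numbers for fast clearance), compound 2 gives 11 mL.min-1.g-1, the only numerical result recorded so far. Among the measured compounds shown here, the one other value recorded, that of compound 1, is a limit. Compound 1 `CN(C)CCN1CCN(c2ccc(Cn3c(=O)[nH]c4c(N)nc(C(F)(F)F)cc43)cn2)CC1` carries 4-(2-(dimethylamino)ethyl)piperazin-1-yl on the aromatic carbon where compound 2 carries (2-(diethylamino)ethyl)(methyl)amino. In this assay compound 1 returns < 8.5 mL.min-1.g-1, which is a limit of the assay rather than a number. For the measured compounds named here, the single measured step, an at least 1.2-fold higher number from compound 1 to compound 2 (0.11 log units; that floor lies within the scatter), therefore has only a floor, and that floor lies within the scatter; it rests on (the limit of < 8.5 mL.min-1.g-1 in this assay, at which 1 of the 2 values shown sits).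

Compound 3 `CN1CCN(CCN(C)c2ccc(Cn3c(=O)[nH]c4c(N)nc(C(F)(F)F)cc43)cn2)CC1` differs from compound 2 by 4-methylpiperazin-1-yl in place of diethylamino on a saturated chain carbon, two bonds along the chain from a nitrogen on an aromatic ring. Going by the values given here, no measured step swaps a terminal dialkylamino group for a cyclic amine on the chain, and the only step recorded, from the piperazine-bearing compound 1 to compound 2, is small and bounded by a limit. The expected movement in this assay is none beyond the scatter, with a slight lean toward slower clearance. Compound 3 is expected to give 9 mL.min-1.g-1, with a range of 5 mL.min-1.g-1 to 17 mL.min-1.g-1, which is estimated as a step of a 1.2-fold lower number from compound 2 to compound 3 (0.09 log units; within the scatter).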

Compound 3, intrinsic clearance in microsomes: 15 mL.min-1.g-1
Compound 3: the middle estimate sits 1.7-fold (0.22 log units) below what was measured; the measured number falls inside the stated range.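

With a numerical value at both ends, exchanging diethylamino for 4-methylpiperazin-1-yl on a saturated chain carbon, two bonds along the chain from a nitrogen on an aromatic ring, gives a 1.4-fold higher number from compound 2 to compound 3 (0.13 log units; within the scatter) in this assay. Among the compounds shown here, this is the first step not bounded by a limit, and it shows that an open terminal amine and a six-membered ring on this chain cannot be told apart in this read-out. The step with methyl(2-(4-methylpiperazin-1-yl)ethyl)amino in place of 4-(2-(dimethylamino)ethyl)piperazin-1-yl on an aromatic carbon, an at least 1.7-fold higher number from compound 1 to compound 3 (0.24 log units; that floor lies within the scatter), adds a second comparison with compound 1, but the value of compound 1 is a limit and not a number, so this step has only a floor: the limit of < 8.5 mL.min-1.g-1 in this assay, at which 1 of the 3 values shown sits.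

On these data alone, how far compound 1 really differs from compound 3 remains open, as the floor does not fix the size of that step. Also open, as far as these compounds go, is whether a morpholine, a pyrrolidine or a primary amine at the end of the same chain, or a longer chain carrying 4-methylpiperazin-1-yl, would move beyond the scatter from compound 2 in this assay.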